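Swapping a benzimidazole for an aza analogue on a shared core

The compounds below may be only part of what the source reports. "The series", "measured", "known", "first", "only" and "open" are said of these compounds alone.

Compound 1, `CCC(c1nc2ncc(Cl)cc2[nH]1)[C@H]1CC[C@@H](c2ccnc3ccc(C(F)(F)F)cc32)CC1`: 2 nM
Compound 2, `COCC(Nc1nnc(-c2ccc(OC)cc2)o1)[C@H]1CC[C@@H](c2ccnc3ccc(F)cc32)CC1`: 3 nM
Compound 3, `CCC(c1nc2ccc(Cl)cc2[nH]1)[C@H]1CC[C@@H](c2ccnc3ccc(F)cc32)CC1`: 2 nM

These three compounds were tested in an assay on tissue (HeLa cells) for inhibition of Indoleamine 2,3-dioxygenase 1 (Homo sapiens), read by fluorescence, with a stated time of 18 h; a higher number here means a weaker inhibitor, a lower number a stronger inhibitor. Compound 3 gives 2 nM, level with compound 1 at the digits shown, and compound 2, at 3 nM, lies within the usual scatter of both, so all three numbers sit within the scatter of one another. Among the measured compounds shown here, no single-change step between measured compounds is available, so the size of any one change has not been measured directly here.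

Compound 4, `CCC(c1nc2ncc(Cl)cc2[nH]1)[C@H]1CC[C@@H](c2ccnc3ccc(F)cc32)CC1`, is not yet measured. It differs from compound 3 in one place: a group of 10 heavy atoms (6 carbon, 3 nitrogen, 1 chlorine; one five-membered aromatic ring with 2 hetero atoms, one six-membered aromatic ring with 1 hetero atom) in place of a group of 10 heavy atoms (7 carbon, 2 nitrogen, 1 chlorine; one five-membered aromatic ring with 2 hetero atoms, one six-membered aromatic ring of carbon only), on a saturated chain carbon bound to a saturated chain carbon and a saturated ring carbon. The group that enters is the same one that compound 1 carries, and compound 1 gives 2 nM in this assay, with its other difference from compound 3 sitting elsewhere on the shared core. Nothing shown here points to this change moving the number beyond the scatter in either direction. The expected step is no change at the digits printed from compound 3 to compound 4 (within the scatter), amounting to no change beyond the scatter. The estimate for compound 4 is 2 nM, within a range from 1 nM to 5 nM.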

Compound 4, half-maximal inhibitory concentration: 2 nM
For compound 4 middle estimate and measured number coincide at the digits printed; measured number inside the range.
By their numbers in this assay, from the lowest: compounds 1, 3, 4 and 2 (each within the scatter of the next).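

Placing a nitrogen in the six-membered aromatic ring of the 6-chloro-1H-benzimidazol-2-yl group, on the saturated chain carbon, gives the first direct reading of this change in this assay (no change at the digits printed from compound 3 to compound 4 (within the scatter)). On the shared core, fluoro in place of trifluoromethyl on an aromatic carbon can now be read directly too (no change at the digits printed from compound 1 to compound 4 (within the scatter)), so neither single change moves the number beyond the scatter in these pairs. Nothing here bears on why these numbers stay level.

As far as these compounds go, both readings come from one pair each, so it remains open whether the ring nitrogen would read the same in other settings on the core. From the compounds shown here alone, it is also open how a nitrile in place of the chlorine, or a methyl in place of the fluoro, would read.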